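This account rests on a few compounds, and the source may have more. Where it says the series, first, only, none or still open, it means among the compounds named here.

Of the compounds shown here, three built on one shared core have been measured in a functional assay on IMR-32 cells (Homo sapiens) for inhibition, read by sulforhodamine B assay, with a stated time of 48 h, tested at 100 uM; a higher number here means more inhibition of growth at the concentration tested, a lower number less inhibition of growth. Compound 1 `O=c1c(C2N=C(c3ccccc3)SS2)coc2cc(Cl)c(Cl)cc12` gives 77%. Compound 2 `O=c1c(C2N=C(c3ccccc3)SS2)coc2ccc(F)cc12` gives 75%. Compound 3 `O=c1c(C2N=C(c3ccccc3)SS2)coc2cc(Cl)ccc12` gives 53%, the lowest of the three numbers; compound 2 sits nearest to it and compound 1 furthest from it, both clearly higher than compound 3 by more than the usual scatter.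

Going by the values given here, only one measured step touches the change ahead. It runs a number 24 percentage points lower from compound 1 to compound 3 (beyond the scatter), and it consists of hydrogen in place of chloro on an aromatic carbon, so that taking a halogen away from the core lowered growth inhibition.

Compound 4 `O=c1c(C2N=C(c3ccccc3)SS2)coc2cc(Cl)c(F)cc12` is the next compound to be measured. It differs from compound 3 by fluoro in place of hydrogen on an aromatic carbon. This move is the reverse in kind of the measured step: a halogen returns to the core, though a smaller one than the chloro that compound 1 carries. Compound 1, which holds two halogens, reached its value of 77%, and compound 2, which holds a single fluoro, reached 75%.

On this basis an upward step is expected for compound 4, of the size a number 17 percentage points higher from compound 3 to compound 4 (beyond the scatter). The estimated value for compound 4 in this assay is 70%, with a likely range from 55% to 85%.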

Compound 4, percent growth inhibition at one concentration: 80%
The estimate for compound 4 lay 10 percentage points below the measured number; low and high end bracket the measured number.
By their numbers in this assay, from the lowest: compound 3; then compounds 2, 1 and 4 (each within the scatter of the next).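

In this assay, placing fluoro on this aromatic carbon, ortho to a chloro group, gives a number 27 percentage points higher from compound 3 to compound 4 (beyond the scatter), so a halogen here matters even when it is the smaller fluoro. Fluoro and chloro cannot be told apart at this position, since exchanging them reads as a number 3 percentage points higher from compound 1 to compound 4 (within the scatter). Chloro in place of hydrogen on the other ring carbon reads as a number 5 percentage points higher from compound 2 to compound 4 (within the scatter), so what removing a chloro costs depends on which halogen stays on the ring, and a single step cannot be carried over from one compound to another: the same change on two cores in this assay, a number 24 percentage points lower (beyond the scatter) from compound 1 to compound 3 and a number 5 percentage points lower (within the scatter) from compound 4 to compound 2, 19 percentage points apart, beyond the scatter of two such steps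

From the compounds shown here alone, whether a methoxy group or an amine on this aromatic carbon would hold the number as the two halogens do remains open, and so does whether a halogen is needed there at all rather than any group larger than hydrogen. All of these numbers also come from a single concentration in one cell line, so they cannot say how the compounds would compare at lower concentrations, where compounds that read alike here might separate.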